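Alkynyl uracil phthalimides: aryl extension of the alkyne

A few compounds are considered here, and "the series" means these few. Any claim that something is new, unique, unknown or untested is made for them only; others in the source may bear on it.

Two compounds of this series have numbers in a functional assay on HepG2 cells (Homo sapiens) for antiproliferative activity, read by MTT assay, with a stated time of 3 days; on this read-out lower numbers stand for stronger inhibition and higher numbers for weaker inhibition. Compound 1 `CCCCC#Cc1cn(C/C=C\CN2C(=O)c3ccccc3C2=O)c(=O)[nH]c1=O` gives 17000 nM. Compound 2 `CCCCC#Cc1cn(C/C=C/CN2C(=O)c3ccccc3C2=O)c(=O)[nH]c1=O` gives 7900 nM. Among the measured compounds shown here, the only measured step is a 2.2-fold lower number from compound 1 to compound 2 (0.33 log units; beyond the scatter); the two compounds have the same atoms and bonds, and the step rests on (the fact that compounds 1 and 2 differ only in the configuration as drawn). Within this pair compound 2 stands lowest in this assay, with compound 1 a higher number beyond the scatter.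

Compound 3 `CCCCCc1ccc(C#Cc2cn(C/C=C/CN3C(=O)c4ccccc4C3=O)c(=O)[nH]c2=O)cc1` keeps the double bond of compound 2 drawn E and changes the alkyne end: 4-pentylphenyl in place of butyl on a triple-bonded carbon. For the measured compounds named here, no measured step in this assay concerns a change of this kind; the single step known is one of configuration alone, and it does not speak to replacing butyl with 4-pentylphenyl on a triple-bonded carbon. No direction can therefore be drawn from the data, and no step beyond the scatter is expected with any confidence, the estimated step being a 1.1-fold lower number from compound 2 to compound 3 (0.05 log units; within the scatter) with a wide range. Compound 3 is expected to give 7000 nM in this assay, estimated between 2000 nM and 25000 nM.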

Compound 3, half-maximal inhibitory concentration: 4300 nM
The estimate for compound 3 lay 1.6-fold (0.21 log units) above the measured number; low and high end bracket the measured number.
By their numbers in this assay, from the lowest: compounds 3 and 2 (each within the scatter of the next); then compound 1.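

In this assay the exchange of butyl for 4-pentylphenyl on a triple-bonded carbon gives a 1.8-fold lower number from compound 2 to compound 3 (0.26 log units; within the scatter) and so stays short of a step beyond the scatter. Among the compounds shown here, this is the first reading at this position, and the earlier pair, which differs only in configuration, could not supply it: with the double bond drawn E, a group of 11 heavy atoms with a six-membered aromatic ring takes the place of one of 4 heavy atoms, and compound 3 still reads level with compound 2. Nothing given on the compounds bears on this result.

The compounds shown leave open how the phenyl ring and the pentyl chain each contribute, since a plain phenyl, a shorter chain such as methyl, or a longer chain such as octyl on the ring would separate the two, and an amine or a carboxylic acid in place of the pentyl chain would test a group with heteroatoms at the alkyne end. They also leave open whether the configuration step seen with butyl holds with 4-pentylphenyl, which would need the double bond of compound 3 drawn Z.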